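Methoxy for Methyl on the Aryl Ring of Compound 2

This account rests on a few compounds, and the source may have more. Where it says the series, first, only, none or still open, it means among the compounds named here.

Measured so far:
compound 1, `CNC(=O)c1cc(C(=O)N[C@H]2CC[C@H](O)CC2)n([C@@H](C)c2cccc(Cl)c2)n1`: 235 nm/s
compound 2, `CNC(=O)c1cc(C(=O)N[C@H]2CC[C@H](O)CC2)c([C@@H](C)c2cccc(C)c2)o1`: 85 nm/s

In an ADME assay for permeability (a higher number here means that the compound crosses the layer faster, a lower number that the compound crosses the layer more slowly), compound 1 gives 235 nm/s, while compound 2 gives 85 nm/s, the lower of the two, and the gap between them lies beyond the scatter. Compound 3, `CNC(=O)c1cc(C(=O)N[C@H]2CC[C@H](O)CC2)c([C@@H](C)c2cccc(OC)c2)o1`, has not yet been measured. Going by the values given here, it differs from compound 2 in one place: methoxy in place of methyl on an aromatic carbon No single-point step between measured compounds exists to guide the expectation, so the change is weighed on its own. Compound 3 is expected to give 70 nm/s (range 35 nm/s to 140 nm/s). That estimate means a step of a 1.2-fold lower number from compound 2 to compound 3 (0.08 log units; within the scatter), a small expected drop that stays within the scatter.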

Compound 3, apparent permeability in the ADME assay: 44 nm/s
For compound 3 the middle estimate is 1.6-fold (0.20 log units) above the measured one; low and high end bracket the measured number.
By their numbers in the ADME assay, from the lowest: compounds 3 and 2 (each within the scatter of the next); then compound 1.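

Going by these compounds alone, in the ADME assay, methoxy in place of methyl on this aromatic carbon, meta to a large group, gives a 1.9-fold lower number from compound 2 to compound 3 (0.29 log units; within the scatter), the first single-place step at this position. In a physicochemical assay for solubility, read by HPLC, in simulated intestinal fluid, with a stated time of 16 h, at pH 6.5 (a lower number here means a less soluble compound, a higher number a more soluble compound), compound 3 gives 868 ug/mL. In the physicochemical assay compound 2 gives > 1000 ug/mL, a limit of the assay, and the step to compound 3 cannot be read in size because of that limit: the limit of > 1000 ug/mL in the physicochemical assay, at which 1 of the 2 values shown sits.

Going by these compounds, whether an amine or a nitrile at this position would move either number stays open. So does whether methoxy in place of methyl gives a similar step on the core of compound 1.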